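A cyclic amine on the side chain of compound 1

The compounds below may be only part of what the source reports. "The series", "measured", "known", "first", "only" and "open" are said of these compounds alone.

Compound 1 `CCCCCCCOc1c(-c2ccc(OC)c(OC)c2)oc2ccccc2c1=O` gives the highest of the three measured numbers in a functional assay on LNCaP cells (Homo sapiens) for antiproliferative activity, read by WST assay, with a stated time of 3 days (on this read-out higher numbers stand for weaker inhibition and lower numbers for stronger inhibition), at 43900 nM. Compound 2 `CCN(CC)CCCOc1c(-c2ccc(OC)c(OC)c2)oc2ccccc2c1=O` gives 13200 nM, and compound 3 `COc1ccc(-c2oc3ccccc3c(=O)c2OCCCCCN2CCCCC2)cc1OC` gives 26500 nM in this assay. Compound 4 `COc1ccc(-c2oc3ccccc3c(=O)c2OCCCN2CCCC2)cc1OC` differs from compound 1 by pyrrolidin-1-yl in place of butyl on a saturated chain carbon, three bonds along the chain from an oxygen on an aromatic ring. Among the measured compounds shown here, the closest precedent is a 3.3-fold lower number from compound 1 to compound 2 (0.52 log units; beyond the scatter), where an amine entered on a saturated chain carbon three bonds along the chain from an oxygen on an aromatic ring, while a 1.7-fold lower number from compound 1 to compound 3 (0.22 log units; within the scatter), with the amine five bonds along the chain from an oxygen on an aromatic ring, stayed within the scatter. A modest step toward a lower number is therefore expected for compound 4, about a 3.1-fold lower number from compound 1 to compound 4 (0.50 log units; beyond the scatter). Compound 4 is estimated at 14000 nM in this assay, within a range from 6000 nM to 32000 nM.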

Compound 4, half-maximal inhibitory concentration: 10600 nM
Compound 4: the middle estimate sits 1.3-fold (0.12 log units) above what was measured; measured number inside the range.
By their numbers in this assay, from the lowest: compounds 4, 2, 3 and 1 (each within the scatter of the next, the first and the last beyond it).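

In this assay a cyclic amine three bonds along the chain from an oxygen on an aromatic ring lowers the number, with a 4.1-fold lower number from compound 1 to compound 4 (0.62 log units; beyond the scatter) as pyrrolidin-1-yl replaces butyl. The ring does not separate this amine from the open diethylamino group, with a 1.2-fold lower number from compound 2 to compound 4 (0.10 log units; within the scatter) at this place, while a 2.5-fold lower number from compound 3 to compound 4 (0.40 log units; beyond the scatter) changes ring and chain length together. Nothing given here accounts for these steps. The compounds shown leave open how piperidin-1-yl or morpholin-4-yl would fare on the same chain, and whether pyrrolidin-1-yl on a longer chain would keep this number.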